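A Sulfur-Bearing Group Replaces Acetyl on a Ring Nitrogen

The source may report more compounds than this note shows. Statements on the series, on what has been measured and on what is new or still open speak of the compounds shown alone.

Two measured compounds share one core and differ only in the group on an amine nitrogen in a ring. Compound 1 `CCCC(=O)N1CCC(CN2CC[C@H](NC(=O)c3cc(Cl)c(N)cc3OC)[C@H](OC)C2)CC1` carries the longer chain there; in an assay on COS-7 cells for displacement of a labelled ligand from 5-hydroxytryptamine receptor 4 (Homo sapiens), read by scintillation counting, with a stated time of 30 min (a lower number here means a stronger inhibitor, a higher number a weaker inhibitor), compound 1 gives 178 nM. For the measured compounds named here, compound 2 `COc1cc(N)c(Cl)cc1C(=O)N[C@H]1CCN(CC2CCN(C(C)=O)CC2)C[C@H]1OC` carries an acetyl group at that place, and in this assay compound 2 gives 592 nM, the highest of the two numbers measured so far. The step of a 3.3-fold higher number from compound 1 to compound 2 (0.52 log units; beyond the scatter) is modest but beyond the scatter.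

Going by the values given here, compound 3 `COc1cc(N)c(Cl)cc1C(=O)N[C@H]1CCN(CC2CCN(C(=S)C(C)C)CC2)C[C@H]1OC` is not yet measured. a group of 5 heavy atoms (4 carbon, 1 sulfur; no ring) in place of a group of 3 heavy atoms (2 carbon, 1 oxygen; no ring), on an amine nitrogen in a ring The only measured step that bears on this is a 3.3-fold higher number from compound 1 to compound 2 (0.52 log units; beyond the scatter), where shortening the group on that nitrogen raised the number. Among the compounds with values here, compound 3 enlarges the group on the same nitrogen, so a modest move in the opposite direction, toward a lower number, is expected; the exchange of oxygen for sulfur has no measured counterpart here, which widens the uncertainty. The expected step is a 2.4-fold lower number from compound 2 to compound 3 (0.37 log units; beyond the scatter). For compound 3 the estimate in this assay is 250 nM, with a range from 90 nM to 700 nM.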

Compound 3, half-maximal inhibitory concentration: 155 nM
Beside the measured number, compound 3's estimate is 1.6-fold (0.21 log units) above it; measured number inside the range.
By their numbers in this assay, from the lowest: compounds 3 and 1 (each within the scatter of the next); then compound 2.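

In this assay, the sulfur-bearing group of 5 heavy atoms on this ring nitrogen gives a clear gain over acetyl (a 3.8-fold lower number from compound 2 to compound 3 (0.58 log units; beyond the scatter)). Compound 1 had already shown a lower number than compound 2, but only with a group holding oxygen, so a lower number at this position is now seen with two different groups of 5 heavy atoms. Those two groups, one with 4 carbon and 1 oxygen and the other with 4 carbon and 1 sulfur, cannot be told apart in this assay (a 1.1-fold lower number from compound 1 to compound 3 (0.06 log units; within the scatter)), and no measurement shown here explains either step.

The comparison of compound 1 with compound 3 changes two things within one group: oxygen becomes sulfur, and a straight chain becomes a branched one. The isobutyryl group, which has the branched chain of compound 3 with oxygen in place of sulfur, would separate these two changes, while a thioacetyl group would test sulfur on the short chain, and a longer chain would show whether the number keeps falling as the group grows.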